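Benzyl variation on the ribosylated core: compound 3

The source may hold more compounds than are shown below. What is called first, only, known or untested is meant among the compounds shown, and "the series" means these compounds.

Compound 1 `Nc1nc(O)c2c(n1)n(C1OC(CO)[C@@H](O)[C@H]1O)c(=O)n2Cc1ccc(Cl)c(Cl)c1` gives 55% in a functional assay on the whole organism (B cells) with Mus musculus as the target (on this read-out higher numbers stand for larger maximal responses and lower numbers for smaller maximal responses), and stands lowest of the two numbers at hand. Compound 2 `C=CCn1c(=O)n(CCCCCCCC)c2nc(N)nc(O)c21` gives 130% in this assay, a gap beyond the scatter, though the two structures differ in more than one place, so nothing is drawn from that pair. Compound 3 `COc1ccc(Cn2c(=O)n(C3OC(CO)[C@@H](O)[C@H]3O)c3nc(N)nc(O)c32)cc1` carries the change (4-methoxyphenyl in place of 3,4-dichlorophenyl on a saturated chain carbon bound to an aromatic nitrogen). Among the measured compounds shown here, no step between measured compounds bears on this change, so the expected step of a number 10 percentage points higher from compound 1 to compound 3 (within the scatter) is small, with no firm direction. Compound 3 is estimated at 65%, within 35% to 105%.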

Compound 3, largest response reached (reported as maximal response), in percent of the reference or control that the assay uses: 44%
Estimate against measurement, compound 3: 21 percentage points above, and the stated range covers the measured number.
By their numbers in this assay, from the lowest: compound 3; then compound 1; then compound 2.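

In this assay the position on the saturated chain carbon bound to an aromatic nitrogen proves sensitive to the aryl group: 4-methoxyphenyl in place of 3,4-dichlorophenyl gives a number 11 percentage points lower from compound 1 to compound 3 (beyond the scatter) as a modest first single-place step in the series. Nothing at hand accounts for this step.

Plain phenyl or 4-chlorophenyl would be needed to separate the loss of the two chlorines from the gain of the methoxy group. On these data alone, how an amine or a carboxylic acid on this ring would read also remains open.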